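Propyl in Place of Vinyl: A Chain Change Without Precedent

The source may report more compounds than this note shows. Statements on the series, on what has been measured and on what is new or still open speak of the compounds shown alone.

For the measured compounds named here, compound 1 `C=CCN(C)/N=N/c1ccc(C(N)=O)cc1` is one of two compounds measured in a functional assay on L1210 cells (Mus musculus) for antiproliferative activity; on this read-out lower numbers stand for lower potency and higher numbers for higher potency (the scale is a negative logarithm). There compound 1 gives 3.38, the lower of the two numbers, while compound 2 `C=CCN(C)/N=N/c1ccc(NC(N)=O)cc1` gives 3.77. Going by the values given here, the only measured step, a number 0.39 log units higher from compound 1 to compound 2 (beyond the scatter), concerns the group on the aromatic carbon and leaves the chain on the amine nitrogen untouched. Compound 3 `CCCCN(C)/N=N/c1ccc(C(N)=O)cc1` differs from compound 1 in exactly that chain: propyl in place of vinyl on a saturated chain carbon bound to an amine nitrogen. No measured pair speaks to this change, so nothing among the shown values gives ground for expecting a step in this assay beyond the scatter in either direction; the estimate rests on the value of compound 1 alone. Compound 3 is therefore expected to give about 3.4 in this assay, within a range from 2.9 to 3.9. The step this estimate implies, a number 0.02 log units higher from compound 1 to compound 3 (within the scatter), is expected to be small.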

Compound 3, logarithm of the reciprocal of the active concentration, log(1/C) in the L1210 assay: 3.47
Estimate against measurement, compound 3: 0.07 log units below, within the range that was stated.
By their numbers in the L1210 assay, from the lowest: compounds 1, 3 and 2 (each within the scatter of the next, the first and the last beyond it).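

In the L1210 assay the chain on the amine nitrogen now has a measured step of its own, a number 0.09 log units higher from compound 1 to compound 3 (within the scatter), so at this place propyl in place of vinyl leaves the read-out within the scatter. In a physicochemical assay for lipophilicity, measured as octanol-water partition (a higher number here means a more lipophilic compound, a lower number a more polar compound), compound 1 gives 2.09 and compound 3 gives 2.46, so the same change does register on that scale. Across this pair, a rise in lipophilicity therefore comes without a step beyond the scatter in the L1210 assay, the rise itself being read from the physicochemical assay: the measured partition coefficient of compound 1, 2.09, and of compound 3, 2.46, a number 0.37 log units higher (beyond the scatter)

From the compounds shown here alone, whether a longer chain or an amine on this chain would also stay within the scatter in the L1210 assay remains open, as does whether the change behaves alike with the ureido group of compound 2. This single pair also does not separate the loss of the double bond from the added carbon.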